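Prenyl for isopropyl on the ring nitrogen of compound 3

The compounds below may be only part of what the source reports. "The series", "measured", "known", "first", "only" and "open" are said of these compounds alone.

Measured so far in an assay on isolated protein (Oryctolagus cuniculus) with Thromboxane-A synthase (Homo sapiens) as the target, tested at 1 uM; a higher number here means more inhibition at the concentration tested (going by the name of the read-out), a lower number less inhibition:
compound 1 `Oc1nnc(-c2cccnc2)c2ccccc12`: 26%
compound 2 `Cn1nc(-c2cccnc2)c2ccccc2c1=O`: 63%
compound 3 `CC(C)n1nc(-c2cccnc2)c2ccccc2c1=O`: 87%

Compound 3 gives the highest of the three numbers in this assay, beyond the scatter above compound 2 and further still above compound 1. Compound 4 `CC(C)=CCn1nc(-c2cccnc2)c2ccccc2c1=O` differs from it in one place: 3-methylbut-2-en-1-yl in place of isopropyl on an aromatic nitrogen. Going by the values given here, the one step that bears on this change is the growth of the group on the aromatic nitrogen, a number 24 percentage points higher from compound 2 to compound 3 (beyond the scatter), where the number was higher with the larger group. A further enlargement is therefore expected to hold or slightly raise the inhibition in this assay, with little room left above compound 3. Compound 4 is estimated at 90%, between 75% and 98%. That estimate means a step of a number 3 percentage points higher from compound 3 to compound 4 (within the scatter), within the scatter.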

Compound 4, a percentage reported as inhibition, at one concentration (the size of the read-out at that concentration, not a potency): 94%
Compound 4: the middle estimate sits 4 percentage points below what was measured; measured number inside the range.
By their numbers in this assay, from the lowest: compound 1; then compound 2; then compounds 3 and 4 (each within the scatter of the next).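

With 3-methylbut-2-en-1-yl in place of isopropyl, this assay gives a number 7 percentage points higher from compound 3 to compound 4 (within the scatter), so the position accepts this larger group carrying a double bond, without a change that can be told from the scatter. Against the smaller group on the same nitrogen, the result is a number 31 percentage points higher from compound 2 to compound 4 (beyond the scatter), so the gain seen with isopropyl is kept with this chain. Nothing available explains this behaviour at the position.

On these data alone, whether the double bond matters remains open, as a saturated 3-methylbutyl group would test that. Also open, as far as these compounds go, is how an amine or a carboxylic acid at the end of this chain would fare.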